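Lengthening the ester chain of compound 1

The compounds below may be only part of what the source reports. "The series", "measured", "known", "first", "only" and "open" are said of these compounds alone.

Going by the values given here, in a toxicity assay on MRC5 cells (Homo sapiens) for inhibition, read by MTT assay, with a stated time of 72 h (on this read-out higher numbers stand for weaker inhibition and lower numbers for stronger inhibition), compound 1 (`CCCC(=O)OCCc1ccc(O)c(O)c1`) gives 71500 nM as the only actual number so far. Compound 2 (`CCCCCCCCCCC(=O)OCCc1ccc(OCc2ccccc2)c(OCc2ccccc2)c1`) reads > 50000 nM as a limit of the assay. Compound 3 (`CCCCCCCCCCCCSCCc1ccc(OCc2ccccc2)c(OCc2ccccc2)c1`) reads > 50000 nM as a limit of the assay too. Compound 4 (`CCCCCCCCCCCC(=O)OCCc1ccc(O)c(O)c1`) keeps the core of compound 1 and differs by octyl in place of hydrogen on a saturated chain carbon, three bonds along the chain from a carbonyl carbon with octyl in place of hydrogen on a saturated chain carbon, three bonds along the chain from a carbonyl carbon. Among the compounds with values here, no measured pair isolates this change. A moderate step towards stronger inhibition is expected in this assay with wide uncertainty. The estimated step is a 2.4-fold lower number from compound 1 to compound 4 (0.38 log units; beyond the scatter) for now. Compound 4 is expected to give 30000 nM with an estimated range of 8000 nM to 90000 nM in this assay when measured.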

Compound 4, half-maximal inhibitory concentration: 38100 nM
Estimate against measurement, compound 4: 1.3-fold (0.10 log units) below; the range from low to high includes it.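

Octyl in place of hydrogen on a saturated chain carbon, three bonds along the chain from a carbonyl carbon, is the first change in the series that can be read as a number: in this assay the reading is a 1.9-fold lower number from compound 1 to compound 4 (0.27 log units; within the scatter). The data therefore do not tell octyl from hydrogen at this position. Steps to compound 2 and compound 3 cannot be read, as their values are limits: the limit of > 50000 nM in this assay, at which 2 of the 4 values shown sit.

Open, on these data alone, is whether an amine, a carboxylic acid or a chain longer than octyl at this position would give a step beyond the scatter.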